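Adding a chloromethyl group to compound 2

A few compounds are considered here, and "the series" means these few. Any claim that something is new, unique, unknown or untested is made for them only; others in the source may bear on it.

Of the compounds shown here, three sharing one core have been tested in a functional assay on HT-1080 cells (Homo sapiens) for antiproliferative activity, read by sulforhodamine B assay, with a stated time of 48 h; a lower number here means a stronger inhibitor, a higher number a weaker inhibitor. Compound 1 `CCC(=O)Nc1ccc(S(=O)(=O)Oc2ccccc2C(C)C)cc1` gives 2100 nM, compound 3 `CC(C)c1ccccc1OS(=O)(=O)c1ccc(NC(=O)CCl)cc1` gives 1000 nM, and compound 2 `CCC(=O)Nc1ccc(S(=O)(=O)Oc2ccccc2I)cc1` gives 7200 nM, the highest of the three numbers. The step of a 3.4-fold higher number from compound 1 to compound 2 (0.54 log units; beyond the scatter) came from iodo in place of isopropyl on an aromatic carbon. The step of a 2.1-fold lower number from compound 1 to compound 3 (0.32 log units; beyond the scatter) came from chloro in place of methyl on a saturated chain carbon bound to a carbonyl carbon. Compound 4 `O=C(CCCCl)Nc1ccc(S(=O)(=O)Oc2ccccc2I)cc1` differs from compound 2 only in the propanoyl group: chloromethyl in place of hydrogen on a saturated chain carbon, two bonds along the chain from a carbonyl carbon. Within the data shown here, only the step from compound 1 to compound 3 touched this chain, and the present change sits two bonds along the chain from the carbonyl carbon rather than bound to it, so a smaller shift is anticipated. The expected step is a 1.4-fold lower number from compound 2 to compound 4 (0.16 log units; within the scatter). Compound 4 is therefore estimated at 5000 nM, within 2000 nM to 12000 nM.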

Compound 4, half-maximal inhibitory concentration: 12000 nM
The estimate for compound 4 lay 2.4-fold (0.38 log units) below the measured number; the measured number falls inside the stated range.
By their numbers in this assay, from the lowest: compound 3; then compound 1; then compounds 2 and 4 (each within the scatter of the next).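

In this assay, the change from propanoyl to (3-chloropropyl)carbonyl gives a 1.7-fold higher number from compound 2 to compound 4 (0.22 log units; within the scatter), so at this chain carbon the added chloromethyl group produces no shift that can be told from the usual scatter. The earlier chain step, a 2.1-fold lower number from compound 1 to compound 3 (0.32 log units; beyond the scatter), put chloro on a different carbon and started from the isopropyl compound, so it says little about this position. Nothing available explains the result. Open, going by these compounds, is whether a longer chain, or an amine or a carboxylic acid at this carbon, would move the number beyond the scatter.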